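Adding a Methyl Group to an Inactive Phosphoserine Ester

This account rests on a few compounds, and the source may have more. Where it says the series, first, only, none or still open, it means among the compounds named here.

Measured compounds:
- compound 1, `N[C@@H](COP(=O)(O)O[C@@H]1CCCO[C@@H]1COC(=O)CCc1ccccc1OCc1cccc(Oc2ccc(Cl)cc2)c1)C(=O)O`: "not active" (no number reported)
- compound 2, `N[C@@H](COP(=O)(O)O[C@@H]1CCCO[C@@H]1COC(=O)CCc1ccccc1OCc1cccc(Oc2ccccc2)c1)C(=O)O`: "not active" (no number reported)
- compound 3, `CCCCCCCCCCCOc1ccccc1CCC(=O)OC[C@H]1OCCC[C@@H]1OP(=O)(O)OC[C@H](N)C(=O)O`: 7.5%

All three share the same core, a phosphoserine joined through a cyclic ether to an ester-linked aryl chain, and were tested in an assay on HEK293-A cells for agonist activity at putative P2Y purinoceptor 10 (Mus musculus), with a stated time of 1.5 h; on this read-out higher numbers stand for larger maximal responses and lower numbers for smaller maximal responses. Compound 2 stands without a number: in this assay compound 2 is reported as "not active" (no number reported), and compound 1 is reported the same way. Only compound 3 carries a number, giving 7.5% in this assay, a small maximal response.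

Compound 4, `Cc1ccc(Oc2cccc(COc3ccccc3CCC(=O)OC[C@H]3OCCC[C@H]3OP(=O)(O)OC[C@H](N)C(=O)O)c2)cc1`, is the next step from compound 2. The difference is methyl in place of hydrogen on an aromatic carbon, a methyl in place of hydrogen on an aromatic carbon of the outermost ring.

Among the compounds with values here, no step between measured compounds is available, so the size of this change cannot be read from earlier pairs. With compound 2 showing no activity and compound 3 reaching only a small response, no large move in either direction is expected, and a result of no activity would not be surprising. Compound 4 is expected to give 5%, within a range from 0% to 15%.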

Compound 4, largest response reached (Emax), in percent of the reference or control that the assay uses: "not active" (no number reported)
No number was reported for compound 4; there is nothing to compare the estimate with.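

Compound 2 and compound 4 both stand without a number, so no step can be read from the change of hydrogen to methyl. Nothing measured here bears on this result. The compounds shown leave open whether any group at this place can produce a measurable response.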